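This account rests on a few compounds, and the source may have more. Where it says the series, first, only, none or still open, it means among the compounds named here.

Measured in a functional assay on RS4-11 cells (Homo sapiens) for antiproliferative activity, read by MTT assay, with a stated time of 48 h; a higher number here means that more compound is needed for the effect, a lower number that less compound is needed:
- Compound 1 `COC(=O)c1[nH]c2cc(OC)ccc2c1-c1ccc(Br)cc1`: 200 nM
- Compound 2 `COC(=O)c1[nH]c2cc(OC)ccc2c1C`: > 100000 nM, a limit
- Compound 3 `CCc1c(C(=O)OC)[nH]c2cc(OC)ccc12`: > 100000 nM, a limit

Compound 3 therefore stands at a limit of this assay, not at a true number. Compound 4 `COC(=O)c1[nH]c2cc(OC)ccc2c1C(C)C` differs from it by one change, ethyl to isopropyl: methyl in place of hydrogen on a saturated chain carbon bound to an aromatic carbon and a saturated chain carbon. The closest measured change is a step that the two limits leave unreadable from compound 2 to compound 3. Two other steps replace the 4-bromophenyl with a short chain: an at least 500-fold higher number from compound 1 to compound 2 (2.69 log units; beyond the scatter) and an at least 500-fold higher number from compound 1 to compound 3 (2.69 log units; beyond the scatter). Compound 4 also lacks the 4-bromophenyl, so no recovery is expected. The expected change is a number no higher from compound 3 to compound 4 (the limit leaves the size open), probably too small to read, much as in a step that the two limits leave unreadable from compound 2 to compound 3. For compound 4 the estimate is 100000 nM, with an expected range from 20000 nM to 200000 nM.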

Compound 4, half-maximal effective concentration: 81500 nM
The estimate for compound 4 lay 1.2-fold (0.09 log units) above the measured number, and the stated range covers the measured number.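

For the compounds shown here, compound 4 is the first compound here with a short chain at this position to give a true number, not a limit, yet this amounts only to an at least 1.2-fold lower number from compound 3 to compound 4 (0.08 log units; that floor lies within the scatter) and an at least 1.2-fold lower number from compound 2 to compound 4 (0.08 log units; that floor lies within the scatter). Both steps are only floors, because compound 2 and compound 3 each stand at a limit: the limit of > 100000 nM in this assay, at which 2 of the 4 values shown sit. Isopropyl therefore does not make up for losing the 4-bromophenyl, with a 410-fold higher number from compound 1 to compound 4 (2.61 log units; beyond the scatter).

As far as these compounds go, whether a plain phenyl or a longer chain such as butyl would work here remains open. The compounds shown therefore cannot separate the part played by the ring from that of the bromine.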